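The source may hold more compounds than are shown below. What is called first, only, known or untested is meant among the compounds shown, and "the series" means these compounds.

Of the compounds shown here, three sharing one core have been measured in a functional assay (aorta) with Rattus norvegicus as the target; on this read-out higher numbers stand for weaker inhibition and lower numbers for stronger inhibition. Compound 1 `CC1(C)Oc2ccc(C#N)cc2[C@@H](NC(=O)c2ccccc2)[C@@H]1O` gives 30 nM. For the measured compounds named here, compound 2 `C/N=C(\NC#N)N[C@@H]1c2cc(C#N)ccc2OC(C)(C)[C@H]1O` gives 200 nM in this assay, and the step of a 6.7-fold higher number from compound 1 to compound 2 (0.82 log units; beyond the scatter) is the only single-point change measured so far. Compound 3 `CC1(C)Oc2ccc(C#N)cc2[C@@H](/N=C(\NC#N)Nc2ccc([N+](=O)[O-])cc2)[C@@H]1O` gives 300 nM in this assay; this is the highest of the three numbers, though its gap to compound 2 lies within the scatter, while its gap to compound 1 lies beyond it.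

Compound 4 `CSc1ccc(N/C(=N/[C@@H]2c3cc(C#N)ccc3OC(C)(C)[C@H]2O)NC#N)cc1` has not yet been measured. It differs from compound 3 by methylsulfanyl in place of nitro on an aromatic carbon. Going by the values given here, no measured step bears directly on this: the one measured step, a 6.7-fold higher number from compound 1 to compound 2 (0.82 log units; beyond the scatter), exchanged the whole group on the amine nitrogen, and the two compounds carrying the cyanoguanidine, compound 2 and compound 3, have values within the scatter of each other. Exchanging one group for another on the six-membered aromatic ring of carbon only is therefore expected to move the number little, probably not beyond the scatter. The step of a 1.2-fold lower number from compound 3 to compound 4 (0.08 log units; within the scatter) is what is expected. Compound 4 is estimated at 250 nM in this assay, with a range from 80 nM to 800 nM.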

Compound 4, half-maximal inhibitory concentration: 6300 nM
Beside the measured number, compound 4's estimate is 25-fold (1.40 log units) below it; the whole stated range lies below it.
By their numbers in this assay, from the lowest: compound 1; then compounds 2 and 3 (each within the scatter of the next); then compound 4.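

In this assay the group on the aromatic ring clearly matters: a 21-fold higher number from compound 3 to compound 4 (1.32 log units; beyond the scatter) is a large step for methylsulfanyl in place of nitro on a single aromatic carbon, para to a large group. For the compounds shown here, the only earlier step exchanged the whole group on the amine nitrogen, so this is the first sign that one ring position can by itself move the number well beyond the scatter. Nothing measured here accounts for the step.

Going by these compounds, whether the weakening comes from losing nitro or from adding methylsulfanyl remains open, and a chlorine, an amine or a carboxylic acid at this place would help separate the two. On these data alone, it is also open whether the same exchange would have a similar effect on the phenyl ring of the amide in compound 1.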